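A few compounds are considered here, and "the series" means these few. Any claim that something is new, unique, unknown or untested is made for them only; others in the source may bear on it.

Measured so far in an ADME assay on HeLa cells (Homo sapiens) for cytotoxicity, read by MTT assay; a lower number here means a stronger inhibitor, a higher number a weaker inhibitor
compound 1 `COC(=O)CNC(=O)CCC(=O)Oc1ccc(C[C@H]2C(=O)OC[C@@H]2Cc2ccc(OC)c(OC)c2)cc1OC` gives 179000 nM
compound 2 `CCN1CCN(C(=O)CCC(=O)Oc2ccc(C[C@H]3C(=O)OC[C@@H]3Cc3ccc(OC)c(OC)c3)cc2OC)CC1` gives 190000 nM
compound 3 `COC(=O)[C@@H](NC(=O)CCC(=O)Oc1ccc(C[C@H]2C(=O)OC[C@@H]2Cc2ccc(OC)c(OC)c2)cc1OC)C(C)C` gives 64000 nM

Compound 3 has the lowest number of the three. Both of its steps lie beyond the scatter and are modest (a 2.8-fold lower number from compound 1 to compound 3 (0.45 log units; beyond the scatter) and a 3.0-fold lower number from compound 2 to compound 3 (0.47 log units; beyond the scatter)). Compound 1 and compound 2 are not separated (a 1.1-fold higher number from compound 1 to compound 2 (0.03 log units; within the scatter)).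

Next is compound 4 `COC(=O)[C@H](CC(C)C)NC(=O)CCC(=O)Oc1ccc(C[C@H]2C(=O)OC[C@@H]2Cc2ccc(OC)c(OC)c2)cc1OC`, not yet measured. The change from compound 3 is isobutyl in place of isopropyl on a saturated chain carbon bound to an amide-type nitrogen and a carbonyl carbon and amounts to isobutyl in place of isopropyl on a saturated chain carbon bound to an amide-type nitrogen and a carbonyl carbon.

Within the data shown here, the closest evidence is the one measured step at that same carbon, where isopropyl took the place of hydrogen (a 2.8-fold lower number from compound 1 to compound 3 (0.45 log units; beyond the scatter)). The step of a 3.0-fold lower number from compound 2 to compound 3 (0.47 log units; beyond the scatter) replaces the whole group on the carbonyl carbon, so it bears on this change less directly. Isobutyl differs from isopropyl far less than isopropyl differs from hydrogen, so no step beyond the scatter is expected in this assay, with only a slight lean towards a lower number. The estimated step is a 1.1-fold lower number from compound 3 to compound 4 (0.06 log units; within the scatter) and is expected to stay within the scatter. Compound 4 is therefore estimated at 56000 nM with an expected range (26000 nM to 120000 nM).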

Compound 4, half-maximal inhibitory concentration: 53200 nM
Compound 4: middle estimate off by 1.1-fold (0.02 log units), on the high side; measured number inside the range.
By their numbers in this assay, from the lowest: compounds 4 and 3 (each within the scatter of the next); then compounds 1 and 2 (each within the scatter of the next).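

In this assay, among these compounds, the first change among alkyl groups at this position, isobutyl in place of isopropyl on a saturated chain carbon bound to an amide-type nitrogen and a carbonyl carbon, gives no separation (a 1.2-fold lower number from compound 3 to compound 4 (0.08 log units; within the scatter)), so the added carbon leaves the read-out within the scatter. Isobutyl in place of hydrogen at the same carbon gives a modest step beyond the scatter (a 3.4-fold lower number from compound 1 to compound 4 (0.53 log units; beyond the scatter)), and (1-(methoxycarbonyl)-3-methylbutyl)amino in place of 4-ethylpiperazin-1-yl on a carbonyl carbon does the same (a 3.6-fold lower number from compound 2 to compound 4 (0.55 log units; beyond the scatter)), so the separation from hydrogen at this carbon is now seen with two alkyl groups rather than with isopropyl alone. No supporting measurement accompanies these numbers that could account for the steps, so they stand as observed differences only.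

Open, going by these compounds, is whether a longer chain such as n-hexyl, or a benzyl group, at this carbon would move the number beyond the scatter from compound 4. Also open, on these data alone, is whether a carboxylic acid in place of the methyl ester would keep the separation from compound 1 and compound 2.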